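Amide nitrogen substituents on a shared core: compound 3 to compound 4

The compounds below may be only part of what the source reports. "The series", "measured", "known", "first", "only" and "open" are said of these compounds alone.

Three measured compounds share one core and differ only in the group on the amide-type nitrogen. Compound 1 `COc1cc2c(cc1OC)C(CC(=O)NC(C)C)CC2` carries isopropyl, and in a functional assay on the whole organism (strain Wistar) for inhibition, with Rattus norvegicus as the target, read by paw edema, with stated times of 60 min and 24 h, at a dose of 100 mg/kg by the oral route (a higher number here means more inhibition at the dose given (going by the name of the read-out), a lower number less inhibition), compound 1 gives 30%. Compound 2 `CCCCNC(=O)CC1CCc2cc(OC)c(OC)cc21` carries butyl, and in this assay compound 2 gives 36.7%. Compound 3 `COc1cc2c(cc1OC)C(CC(=O)NC(C)(C)C)CC2` carries tert-butyl, and in this assay compound 3 gives 40%, the highest of the three numbers, though the gaps to the others, a number 3.3 percentage points higher from compound 2 to compound 3 (within the scatter) and a number 10 percentage points higher from compound 1 to compound 3 (within the scatter), both lie within the scatter, as does a number 6.7 percentage points higher from compound 1 to compound 2 (within the scatter). Going by the values given here, none of the measured numbers separates one amide substituent from another.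

Compound 4 `COc1cc2c(cc1OC)C(CC(=O)NC1CCCC1)CC2` is the next member: cyclopentyl in place of tert-butyl on an amide-type nitrogen. All three measured steps bear on this change, since each exchanges one group on the amide-type nitrogen for another, and none moved the number beyond the scatter. The expectation is accordingly for no step beyond the scatter in this assay, in either direction. The step expected is no change at the digits printed from compound 3 to compound 4 (within the scatter). For compound 4 in this assay the estimate is 40%, with a range from 28% to 52%. The width of that range reflects the scatter of repeated measurements; the measured data give no ground to expect more.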

Compound 4, a percentage reported as inhibition, in the whole organism at one dose (the size of the read-out at that dose, not a potency): 46.7%
Compound 4: the middle estimate sits 6.7 percentage points below what was measured; the measured number falls inside the stated range.
By their numbers in this assay, from the lowest: compounds 1, 2, 3 and 4 (each within the scatter of the next, the first and the last beyond it).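

Working notes on the amide nitrogen position. In this assay, going by these compounds alone, this position now gives its first step beyond the scatter, a number 16.7 percentage points higher from compound 1 to compound 4 (beyond the scatter), so cyclopentyl and isopropyl on the amide-type nitrogen are the one pair of groups that the numbers separate. The other two steps, a number 6.7 percentage points higher from compound 3 to compound 4 (within the scatter) and a number 10 percentage points higher from compound 2 to compound 4 (within the scatter), stay within the scatter, so cyclopentyl cannot be told apart from tert-butyl or from butyl, and the separation rests on a single pair, with compound 2 and compound 3 within the scatter of both compound 1 and compound 4. No accompanying measurement bears on this result, and the step therefore stands without an explanation.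

The compounds shown leave open whether the separation from isopropyl belongs to the ring of cyclopentyl as such, a question that cyclopropyl, cyclohexyl or an open pentyl chain on the same nitrogen would bear on. Also open, going by these compounds, is how the number responds to groups of another kind at this position, such as phenyl, benzyl or a chain ending in a hydroxyl or an amine, and each reading here is a single-dose size of effect, not a potency.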